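Reversing an amide on a pyrazole-type core for EP1 binding

The compounds below may be only part of what the source reports. "The series", "measured", "known", "first", "only" and "open" are said of these compounds alone.

Compound 1 `CNC(=O)c1cc(C)n(Cc2cc(Cl)ccc2OCc2ccccc2)n1` carries a methylcarbamoyl group on the shared core. For the measured compounds named here, in an assay on CHO-K1 cells for displacement of a labelled ligand from prostaglandin E2 receptor EP1 subtype (Homo sapiens) (a lower number here means a stronger inhibitor, a higher number a weaker inhibitor), compound 1 gives 100 nM, the highest of the three numbers measured so far. Compound 2 `Cc1cc(NC(=O)CC(C)(C)C)nn1Cc1cc(Cl)ccc1OCc1ccccc1`, which bears a (neopentylcarbonyl)amino group in the same place, gives 10 nM in this assay, and compound 3 `Cc1cc(NC(=O)C2CCOCC2)nn1Cc1cc(Cl)ccc1OCc1ccccc1`, with a ((oxan-4-yl)carbonyl)amino group there, gives 63.1 nM.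

The step to the unmeasured compound 4 `Cc1cc(NC(=O)OC(C)(C)C)nn1Cc1cc(Cl)ccc1OCc1ccccc1` is (tert-butoxycarbonyl)amino in place of methylcarbamoyl on an aromatic carbon. The new group sits on an aromatic carbon of a five-membered aromatic ring with 2 nitrogen, next to the ring nitrogen.

Going by the values given here, two measured steps bear on this change, since both also replace the methylcarbamoyl group with a nitrogen-linked carbonyl group: a 10-fold lower number from compound 1 to compound 2 (1.00 log units; beyond the scatter) and a 1.6-fold lower number from compound 1 to compound 3 (0.20 log units; within the scatter). The first is a modest drop beyond the scatter, the second lies within it, so the direction is downward and its size depends on what follows the carbonyl. The tert-butoxycarbonyl group is closer in shape to the neopentyl chain of compound 2 than to the ring of compound 3, so a lower number is expected for compound 4, estimated as a 5.0-fold lower number from compound 1 to compound 4 (0.70 log units; beyond the scatter). For compound 4 the estimate in this assay is 20 nM, with a range from 6 nM to 63 nM.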

Compound 4, half-maximal inhibitory concentration: 25.1 nM
Compound 4: the middle estimate sits 1.3-fold (0.10 log units) below what was measured; the range from low to high includes it.
By their numbers in this assay, from the lowest: compound 2; then compound 4; then compounds 3 and 1 (each within the scatter of the next).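

With the (tert-butoxycarbonyl)amino group in place, this assay shows a 4.0-fold lower number from compound 1 to compound 4 (0.60 log units; beyond the scatter) and thus gives a second nitrogen-linked carbonyl group, after that of compound 2, with a step beyond the scatter; compound 3 goes against this pattern, as its step from compound 1 stays within the scatter. The tert-butoxy group also adds a middle point to the series of groups on the carbonyl, with a 2.5-fold lower number from compound 3 to compound 4 (0.40 log units; beyond the scatter) on one side and a 2.5-fold higher number from compound 2 to compound 4 (0.40 log units; beyond the scatter) on the other, so the group attached to that carbonyl changes the number in graded steps. Nothing available here accounts for these differences.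

The compounds shown leave open how much of the drop comes from turning the amide around and how much from the group attached to the carbonyl, a question that an acetylamino group, with only a methyl on the carbonyl, would help to separate. They also leave open how a straight butyl chain or a dimethylamino group on that carbonyl would compare with the neopentyl and tert-butoxy groups.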